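Swapping the aryl group on an aminothiophene ketone core

The source may report more compounds than this note shows. Statements on the series, on what has been measured and on what is new or still open speak of the compounds shown alone.

Measured compounds:
- compound 1, `COc1cc(C(=O)c2sc(-c3ccc(Cl)c(Cl)c3)cc2N)cc(OC)c1OC`: 400 nM
- compound 2, `COc1cc(C(=O)c2sc(-c3ccc(C(F)(F)F)cc3)cc2N)cc(OC)c1OC`: 540 nM
- compound 3, `COc1cc(C(=O)c2sc(-c3ccsc3)cc2N)cc(OC)c1OC`: 3.7 nM

In a functional assay on FM3A cells (Mus musculus) for antiproliferative activity (a lower number here means a stronger inhibitor, a higher number a weaker inhibitor), compound 1 gives 400 nM, the second highest of the three numbers. Compound 4, `COc1cc(C(=O)c2sc(-c3ccc(I)cc3)cc2N)cc(OC)c1OC`, has not been measured; it differs from compound 1 in one place: 4-iodophenyl in place of 3,4-dichlorophenyl on an aromatic carbon.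

The step that bears on this change is a 1.4-fold higher number from compound 1 to compound 2 (0.13 log units; within the scatter), where one substituted phenyl replaced another. The large step of a 110-fold lower number from compound 1 to compound 3 (2.03 log units; beyond the scatter) replaced the phenyl with thiophen-3-yl, which compound 4 does not do. Compound 4 is therefore expected to stay close to compound 1, with a 1.1-fold higher number from compound 1 to compound 4 (0.05 log units; within the scatter). The estimate for compound 4 is 450 nM, ranging from 150 nM to 1400 nM.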

Compound 4, half-maximal inhibitory concentration: 420 nM
The estimate for compound 4 lay 1.1-fold (0.03 log units) above the measured number; the measured number falls inside the stated range.
By their numbers in this assay, from the lowest: compound 3; then compounds 1, 4 and 2 (each within the scatter of the next).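

In this assay a third substituted phenyl falls in with the other two, with a 1.1-fold higher number from compound 1 to compound 4 (0.02 log units; within the scatter) and with a 1.3-fold lower number from compound 2 to compound 4 (0.11 log units; within the scatter) as well. At this position, 4-iodophenyl, 3,4-dichlorophenyl and 4-(trifluoromethyl)phenyl cannot be told apart in this assay. The large gap to thiophen-3-yl now holds for a third phenyl too, with a 110-fold higher number from compound 3 to compound 4 (2.06 log units; beyond the scatter) here.

As far as these compounds go, whether a phenyl bearing an amine or a carboxylic acid would stay with these three or move toward compound 3 remains open. Nothing available explains the gap between the phenyls and thiophen-3-yl.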